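A few compounds are considered here, and "the series" means these few. Any claim that something is new, unique, unknown or untested is made for them only; others in the source may bear on it.

Measured compounds:
compound 1 `Cn1c(N2N=C(c3ccccc3)CC2c2ccccc2)nc(-c2ccc(Cl)cc2)c(C#N)c1=O`, 29100 nM;
compound 2 `Cn1c(N2N=C(c3ccccc3)CC2c2ccc(Cl)cc2)nc(-c2ccc(Cl)cc2)c(C#N)c1=O`, 25100 nM;
compound 3 `COc1ccc(C2CC(c3ccccc3)=NN2c2nc(-c3ccc(Cl)cc3)c(C#N)c(=O)n2C)cc1`, 19500 nM.

All three were tested in a functional assay on MDA-MB-231 cells (Homo sapiens) for antiproliferative activity, with a stated time of 72 h; a lower number here means a stronger inhibitor, a higher number a weaker inhibitor. Compound 3 sits with the other two, since the steps from compound 1 to compound 3 a 1.5-fold lower number from compound 1 to compound 3 (0.17 log units; within the scatter) and from compound 2 to compound 3 a 1.3-fold lower number from compound 2 to compound 3 (0.11 log units; within the scatter) both lie within the scatter. Compound 4 `Cn1c(N2N=C(c3ccccc3)CC2c2ccc(F)cc2)nc(-c2ccc(Cl)cc2)c(C#N)c1=O` differs from compound 3 by fluoro in place of methoxy on an aromatic carbon. The three measured steps all change the same aromatic carbon: a 1.2-fold lower number from compound 1 to compound 2 (0.06 log units; within the scatter), a 1.5-fold lower number from compound 1 to compound 3 (0.17 log units; within the scatter), a 1.3-fold lower number from compound 2 to compound 3 (0.11 log units; within the scatter), none beyond the scatter. Another swap at that carbon is therefore expected to give no step beyond the scatter, a 1.2-fold higher number from compound 3 to compound 4 (0.09 log units; within the scatter). Compound 4 is expected at 24000 nM, between 12000 nM and 48000 nM.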

Compound 4, half-maximal inhibitory concentration: 20900 nM
Estimate against measurement, compound 4: 1.1-fold (0.06 log units) above; the measured number falls inside the stated range.
By their numbers in this assay, from the lowest: compounds 3, 4, 2 and 1 (each within the scatter of the next).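

In this assay, fluoro at this aromatic carbon, para to a large group, stays within the scatter of all three earlier substituents (a 1.1-fold higher number from compound 3 to compound 4 (0.03 log units; within the scatter); a 1.2-fold lower number from compound 2 to compound 4 (0.08 log units; within the scatter); a 1.4-fold lower number from compound 1 to compound 4 (0.14 log units; within the scatter)). The set at this carbon now holds hydrogen, two halogens and methoxy, and even the change from 4-methoxyphenyl to 4-fluorophenyl, which replaces a group with one hydrogen-bond acceptor by a group with none, gives no step beyond the scatter. No measurement at hand accounts for this. The compounds shown leave open whether an amine or a carboxylic acid at this carbon would give a step beyond the scatter, and whether a change elsewhere on the shared core, such as at the nitrile, would do so.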